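Moving from methyl to trifluoromethyl on the benzoyl ring

The source may hold more compounds than are shown below. What is called first, only, known or untested is meant among the compounds shown, and "the series" means these compounds.

Of the compounds shown here, two built on a shared core have been tested in a functional assay on CNE-2 cells (Homo sapiens) for cytotoxicity, read by MTT assay, with a stated time of 72 h; a higher number here means a weaker inhibitor, a lower number a stronger inhibitor. Compound 1 `COc1cc2ncnc(NNC(=S)NC(=O)c3ccccc3Cl)c2cc1OC` gives 9670 nM. Compound 2 `COc1cc2ncnc(NNC(=S)NC(=O)c3ccc(C)cc3)c2cc1OC` gives 33300 nM, the higher of the two values and therefore the weaker inhibitor. Going by the values given here, the one step that connects them, a 3.4-fold higher number from compound 1 to compound 2 (0.54 log units; beyond the scatter), shows that swapping the group on the carbonyl carbon shifts the result to a modest degree.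

Compound 3 `COc1cc2ncnc(NNC(=S)NC(=O)c3ccc(C(F)(F)F)cc3)c2cc1OC` differs from compound 2 by a single change: trifluoromethyl in place of methyl on an aromatic carbon. Among the compounds with values here, no measured step covers this exact exchange, so the only guide is the step from compound 1 to compound 2, which tells that a change on this ring can move the number beyond the scatter but not by a large margin. On that basis, a step of comparable or smaller size is expected, and its direction cannot be read from the data. The expected step in this assay for compound 3 is a 1.3-fold lower number from compound 2 to compound 3 (0.12 log units; within the scatter). In this assay compound 3 is estimated at 25000 nM, with a plausible range from 8000 nM to 75000 nM.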

Compound 3, half-maximal inhibitory concentration: 16500 nM
Estimate against measurement, compound 3: 1.5-fold (0.18 log units) above; the range from low to high includes it.
By their numbers in this assay, from the lowest: compounds 1, 3 and 2 (each within the scatter of the next, the first and the last beyond it).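

On the ring of compound 2, para to a large group, putting trifluoromethyl in place of methyl gives a 2.0-fold lower number from compound 2 to compound 3 (0.30 log units; within the scatter) in this assay, so this exchange cannot be told apart from the ordinary spread of repeated measurements. The other step, a change from 2-chlorophenyl to 4-(trifluoromethyl)phenyl on the carbonyl carbon, gives a 1.7-fold higher number from compound 1 to compound 3 (0.23 log units; within the scatter), which also lies within the scatter, so compound 3 cannot be separated from compound 1 or compound 2, even though those two compounds can be separated from each other. The data shown offer no independent measurement that could explain these numbers.

The three compounds cannot show whether the gap between compound 1 and compound 2 depends on the identity of the group or on where it sits on the ring. On these data alone, it also remains open whether an amine, a carboxylic acid or a longer chain at the position held by methyl in compound 2 would move the number beyond the scatter.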